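Three Tolerated Sulfonamides and a Fourth Still to Measure

A few compounds are considered here, and "the series" means these few. Any claim that something is new, unique, unknown or untested is made for them only; others in the source may bear on it.

Of the compounds shown here, three have been measured in an ADME assay on HEK293 cells (Homo sapiens) for cytotoxicity, read by resazurin assay, with a stated time of 48 h; a higher number here means that more compound is tolerated, a lower number that less compound is tolerated. For each of them the result is a limit of the assay rather than a number:

Compound 1 `O=S(=O)(Nc1ccc(-c2nc3ccccc3o2)cc1)c1cccc(F)c1` gives > 100000 nM in this assay.
Compound 2 `O=S(=O)(Nc1ccc(-c2nc3ccccc3o2)cc1)c1cccc(C(F)(F)F)c1` gives > 100000 nM in this assay.
Compound 3 `O=S(=O)(Nc1ccc(-c2nc3ccccc3o2)cc1)c1ccc(F)cc1` gives > 100000 nM in this assay.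

All three share one core and differ only in the ring on the sulfonyl sulfur. From compound 1 to compound 2 the change is trifluoromethyl in place of fluoro on an aromatic carbon, and the step is a step that the two limits leave unreadable from compound 1 to compound 2. From compound 1 to compound 3 the change is 4-fluorophenyl in place of 3-fluorophenyl on a sulfonyl sulfur, and the step is a step that the two limits leave unreadable from compound 1 to compound 3. Neither step can be read because the limit of > 100000 nM in this assay, at which 3 of the 3 values shown sit, holds every value shown.

Compound 4 `O=S(=O)(Nc1ccc(-c2nc3ccccc3o2)cc1)c1ccc(C(F)(F)F)cc1` has not yet been measured. It differs from compound 3 by trifluoromethyl in place of fluoro on an aromatic carbon. This is the same kind of change as from compound 1 to compound 2, but the place differs: there the group sits meta to a large group, here para to a large group. Compound 4 is expected to take a step of a number no higher from compound 3 to compound 4 (the limit leaves the size open) from compound 3, an expectation resting on compound 1 and compound 2 both sitting at the limit of > 100000 nM in this assay, at which 3 of the 3 values shown sit. Compound 4 is therefore estimated at 100000 nM, with a likely range from 30000 nM to 300000 nM.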

Compound 4, half-maximal cytotoxic concentration: 94000 nM
Beside the measured number, compound 4's estimate is 1.1-fold (0.03 log units) above it; the range from low to high includes it.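

In this assay, trifluoromethyl in place of fluoro, para to a large group, gives an at least 1.0-fold lower number from compound 3 to compound 4 (0.02 log units; that floor lies within the scatter). This shows that a number can be read for compound 4, but the step is only a floor, so it does not show that the change truly lowers the tolerated concentration. The same change at its other place, from compound 1 to compound 2, offers no size to compare, and no step that starts from compound 1 can be read, because these values sit at a limit rather than at numbers: the limit of > 100000 nM in this assay, at which 3 of the 4 values shown sit.

As far as these compounds go, all four compounds carry only fluoro or trifluoromethyl on the ring on the sulfonyl sulfur, so it stays open whether this change behaves alike at both places on that ring or on any other core. From the compounds shown here alone, it also stays open whether an amine, a carboxylic acid or a longer chain on that ring would move the number clearly beyond the scatter.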